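Acetamido in place of trifluoromethyl: compound 2 to compound 3

The source may report more compounds than this note shows. Statements on the series, on what has been measured and on what is new or still open speak of the compounds shown alone.

In a physicochemical assay for solubility (a higher number here means a more soluble compound, a lower number a less soluble compound), compound 1 (`N#Cc1ccc(NC(=O)c2cc(Cl)ccc2O)c(Cl)c1`) gives < 1 ug/mL as a limit of the assay and not as a number. Compound 2 (`O=C(Nc1ccc(C(F)(F)F)cc1Cl)c1cc(Cl)ccc1O`) gives < 1 ug/mL as a limit too, so its standing in the series cannot be placed more closely. Compound 3 (`CC(=O)Nc1ccc(NC(=O)c2cc(Cl)ccc2O)c(Cl)c1`) follows from compound 2 through acetamido in place of trifluoromethyl on an aromatic carbon. For the measured compounds named here, the one measured step that bears on this is a step that the two limits leave unreadable from compound 1 to compound 2 and it gives no size to carry over. All the evidence so far is the limit of < 1 ug/mL in this assay, at which 2 of the 2 values shown sit, and no firm direction follows from it. The estimated step is a number no lower from compound 2 to compound 3 (the limit leaves the size open) in this assay and is expected to be small. For compound 3 the expected value is 1 ug/mL with an estimated range from 0.4 ug/mL to 4 ug/mL and a real chance of another limit.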

Compound 3, solubility: 5.1 ug/mL
Beside the measured number, compound 3's estimate is 5.1-fold (0.71 log units) below it, outside the stated range (above it).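

At this position in this assay, acetamido in place of trifluoromethyl gives an at least 5.1-fold higher number from compound 2 to compound 3 (0.70 log units; beyond the scatter), and acetamido in place of cyano gives an at least 5.1-fold higher number from compound 1 to compound 3 (0.70 log units; beyond the scatter). The position therefore does respond to the group placed on it, which the earlier pair could not show, as the step between compound 1 and compound 2 cannot be read. Compound 3 alone stands clear of the limit of the assay: the limit of < 1 ug/mL in this assay, at which 2 of the 3 values shown sit.

As far as these compounds go, the true size of both steps stays open, as each starts from a compound known only by a limit. From the compounds shown here alone, whether the rise is particular to acetamido also stays open, and an amine, a carboxylic acid or a longer acyl chain at this position would test how far it extends.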